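Removing the hydroxymethyl from the biphenyl of compound 3

A few compounds are considered here, and "the series" means these few. Any claim that something is new, unique, unknown or untested is made for them only; others in the source may bear on it.

The series shares one core, carried by compound 1 `O=C(O)CC/C=C\CO[C@H]1[C@@H](OCc2ccc(-c3ccccc3)cc2)CC[C@@H]1N1CCCCC1`, compound 2 `O=C(O)CC/C=C\CO[C@H]1C(OCc2ccc(-c3ccccc3)cc2)CC[C@@H]1N1CCCCCC1` and compound 3 `O=C(O)CC/C=C\CO[C@H]1[C@@H](OCc2ccc(-c3ccccc3CO)cc2)CC[C@@H]1N1CCCCCC1`. In a functional assay for antagonist activity at thromboxane A2 receptor (Rattus norvegicus) (a higher number here means weaker binding, a lower number tighter binding), compound 1 gives 31.6 nM; 50.1 nM (2 entries), as the several entries the several entries of compound 1 in this assay, 31.6 nM; 50.1 nM (2 entries) show. In this assay compound 2 gives 25.1 nM, and compound 3 gives 12.6 nM. Compound 3 thus holds the lowest of the two single numbers, with compound 2 the nearest, a difference that lies within the scatter of the method, while compound 1 contributes a pair of entries rather than one number.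

Compound 4 `O=C(O)CC/C=C\CO[C@H]1[C@@H](OCc2ccc(-c3ccccc3)cc2)CC[C@@H]1N1CCCCCC1` has not yet been run in this assay. It differs from compound 3 in one place: hydrogen in place of hydroxymethyl on an aromatic carbon. For the measured compounds named here, no measured step of this kind is available here, so the expectation rests on compound 3 and the change itself. The step from compound 3 to compound 4 in this assay is estimated to be small, towards a somewhat higher number, and within the scatter, a 2.0-fold higher number from compound 3 to compound 4 (0.30 log units; within the scatter). Compound 4 is expected to give 25 nM in this assay, within a range from 10 nM to 63 nM.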

Compound 4, dissociation constant: 39.8 nM
The estimate for compound 4 lay 1.6-fold (0.20 log units) below the measured number, and the stated range covers the measured number.
By their numbers in this assay, from the lowest: compounds 3, 2 and 4 (each within the scatter of the next, the first and the last beyond it).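

In this assay, hydrogen in place of hydroxymethyl on this aromatic carbon gives a 3.2-fold higher number from compound 3 to compound 4 (0.50 log units; beyond the scatter). This is the first single change in the series shown to move the number beyond the scatter, so this position, ortho to a large group, does register a change, though the step is modest. The other new step, a 1.6-fold higher number from compound 2 to compound 4 (0.20 log units; within the scatter), lies within the scatter and says little about the stereocentre at the saturated ring carbon, because of how the two compounds are drawn: the fact that one of compounds 2 and 4 is drawn with a defined configuration and the other without, at the place where they differ

Hydroxymethyl is the only group other than hydrogen shown at this carbon, so it remains open whether a methoxymethyl, a carboxylic acid or an amine there would give a number like that of compound 3 or that of compound 4.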